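The source may report more compounds than this note shows. Statements on the series, on what has been measured and on what is new or still open speak of the compounds shown alone.

Measured in an ADME assay on KB cells (Homo sapiens) for cytotoxicity, with a stated time of 48 h; on this read-out lower numbers stand for stronger inhibition and higher numbers for weaker inhibition:
- Compound 1 `C=C1[C@H](C)CCC[C@]1(C)CC/C(C)=C/CC1=C(O)C(=O)C=C(NCC(=O)O)C1=O`: 4 ug/mL
- Compound 2 `COC1=CC(=O)C(O)=C(C/C=C(\C)CC[C@@]2(C)CCC=C(C)[C@H]2C)C1=O`: > 10 ug/mL (a limit)
- Compound 3 `CC1=CCC[C@](C)(CC/C(C)=C/CC2=C(O)C(=O)C=C(N[C@H](C(=O)O)C(C)C)C2=O)[C@@H]1C`: > 10 ug/mL (a limit)

Compound 3 has a limit and no number, and it sits at the limit of > 10 ug/mL in this assay, at which 2 of the 3 values shown sit. Compound 4 `CC1=CCC[C@](C)(CC/C(C)=C/CC2=C(O)C(=O)C=C(NCC(=O)O)C2=O)[C@@H]1C` differs from it by one change: hydrogen in place of isopropyl on a saturated chain carbon bound to an amine nitrogen and a carbonyl carbon. This puts hydrogen in place of isopropyl on a saturated chain carbon bound to an amine nitrogen and a carbonyl carbon, giving (carboxymethyl)amino. Among the compounds with values here, the only measured step, a step that the two limits leave unreadable from compound 2 to compound 3, offers no size to carry over. Although the rest of its structure is not identical to compound 4, compound 1 carries (carboxymethyl)amino and gives 4 ug/mL. The expected change in this assay is therefore towards stronger inhibition, as an at least 2.0-fold lower number from compound 3 to compound 4 (0.30 log units; that floor lies within the scatter). The estimate for compound 4 is 5 ug/mL, with an expected range of 2 ug/mL to 10 ug/mL.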

Compound 4, half-maximal inhibitory concentration: 5.4 ug/mL
Compound 4: the middle estimate sits 1.1-fold (0.03 log units) below what was measured; measured number inside the range.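

With hydrogen in place of isopropyl on this carbon, this assay gives a measured number where there had been only a limit, read as an at least 1.8-fold lower number from compound 3 to compound 4 (0.26 log units; that floor lies within the scatter), and (carboxymethyl)amino in place of methoxy reads as an at least 1.8-fold lower number from compound 2 to compound 4 (0.26 log units; that floor lies within the scatter). Both sizes are only floors because the starting compounds stand at a limit: the limit of > 10 ug/mL in this assay, at which 2 of the 4 values shown sit.

Exchanging one ring-bearing group for another at the far end of the chain reads as a 1.4-fold higher number from compound 1 to compound 4 (0.13 log units; within the scatter), so those two compounds cannot be told apart. The compounds shown leave open how a methyl on this carbon would read, or an amide in place of the carboxylic acid.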